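Isobutyl at the amino acid carbon of a quinone

The source may report more compounds than this note shows. Statements on the series, on what has been measured and on what is new or still open speak of the compounds shown alone.

Compound 1 `CC(C)(C)C1=CC(=O)C=C(NCC(=O)O)C1=O`: 171000 nM
Compound 2 `CC1=CCC[C@H]2[C@](C)(CC3=CC(=O)C=C(N[C@@H](CC(C)C)C(=O)O)C3=O)[C@@H](C)CC[C@]12C`: 10900 nM
Compound 3 `CC1=CCC[C@H]2[C@](C)(CC3=CC(=O)C=C(NCC(=O)O)C3=O)[C@@H](C)CC[C@]12C`: 5840 nM

The measured compounds were tested in a functional assay on MDA-MB-453 cells (Homo sapiens) for cytotoxicity, read by MTT assay, with a stated time of 72 h; a lower number here means a stronger inhibitor, a higher number a weaker inhibitor. Compound 3 gives 5840 nM and compound 2 gives 10900 nM. The pair differs by isobutyl in place of hydrogen on a saturated chain carbon bound to an amine nitrogen and a carbonyl carbon, and the step it made was a 1.9-fold higher number from compound 3 to compound 2 (0.27 log units; within the scatter). Compound 1, built on a different core, gives 171000 nM; the difference between the core of compound 1 and the core of compound 3 is not broken down here.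

Compound 4 `CC(C)C[C@H](NC1=CC(=O)C=C(C(C)(C)C)C1=O)C(=O)O` has not yet been measured. It stands to compound 1 as compound 2 stands to compound 3: the change is isobutyl in place of hydrogen on a saturated chain carbon bound to an amine nitrogen and a carbonyl carbon, the same change at the same kind of place. Going by the values given here, the only guide is the step from compound 3 to compound 2, which stayed within the usual scatter, so no shift beyond the scatter is expected here either, though the core of compound 1 is not the core of compound 3 and the step may not carry over exactly. Compound 4 is therefore expected to sit close to compound 1, with an estimated step of a 1.3-fold higher number from compound 1 to compound 4 (0.13 log units; within the scatter). For compound 4 the estimate in this assay is 230000 nM, expected to fall between 90000 nM and 600000 nM.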

Compound 4, half-maximal inhibitory concentration: 84900 nM
The estimate for compound 4 lay 2.7-fold (0.43 log units) above the measured number, and the stated range ends above it.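

In this assay, isobutyl in place of hydrogen on a saturated chain carbon bound to an amine nitrogen and a carbonyl carbon gave a 2.0-fold lower number from compound 1 to compound 4 (0.30 log units; within the scatter), so on this core the change taken alone produced no shift that can be told from the noise of the measurement. Set beside the same change on the other core, the two steps point in opposite directions, and the gap between them is larger than two such steps would be expected to show by scatter alone: the same change on two cores in this assay, a 1.9-fold higher number (0.27 log units; within the scatter) from compound 3 to compound 2 and a 2.0-fold lower number (0.30 log units; within the scatter) from compound 1 to compound 4, 3.8-fold (0.58 log units) apart, beyond the scatter of two such steps This suggests that the step seen on one core could not be carried over as a fixed number to the other, but it rests on a single pair per core, each step is small on its own, and it gives no reason for the difference and no rule for any further core in the series.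

The compounds shown leave open how a methyl or a benzyl group at that same carbon would behave on either core. They also leave open whether the disagreement between the two steps would persist with a methyl ester or a primary amide in place of the carboxylic acid.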